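Trading Chloro for Bromo on Compound 3

The compounds below may be only part of what the source reports. "The series", "measured", "known", "first", "only" and "open" are said of these compounds alone.

Among the measured compounds shown here, in an ADME assay on BJ cells (Homo sapiens) for cytotoxicity, read by fluorescence, with a stated time of 24 h (on this read-out lower numbers stand for stronger inhibition and higher numbers for weaker inhibition), compound 3 `CCC1S/C(=N\N=C\c2c(-c3ccc(Cl)cc3)[nH]c3ccccc23)NC1=O` gives 7450 nM as the lowest of the two actual numbers so far. Compound 2 `CCC1S/C(=N\N=C\c2c(-c3ccc([N+](=O)[O-])cc3)[nH]c3ccccc23)NC1=O` gives 29800 nM and so stands higher. Compound 1 `CC1S/C(=N\N=C\c2c(-c3ccc(Br)cc3)[nH]c3ccccc23)NC1=O` carries a bromo and reads > 50000 nM as a limit of the assay, not a number.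

Compound 4 `CCC1S/C(=N\N=C\c2c(-c3ccc(Br)cc3)[nH]c3ccccc23)NC1=O` differs from compound 3 by a single swap, bromo in place of chloro on an aromatic carbon with bromo in place of chloro on an aromatic carbon, so 4-chlorophenyl becomes 4-bromophenyl. For the measured compounds named here, the one measured step at this place is a 4.0-fold lower number from compound 2 to compound 3 (0.60 log units; beyond the scatter) for chloro in place of nitro, and it was modest.

The new swap exchanges one atom for one atom, so a smaller step is expected in this assay and it may stay within the scatter. Going by the values given here, a slight lean toward a higher number rests on compound 1 and its limit of > 50000 nM as the only bromo reading so far. The expected step is a 1.2-fold higher number from compound 3 to compound 4 (0.08 log units; within the scatter) by this estimate. Compound 4 is expected at 9000 nM with an estimated range of 3500 nM to 25000 nM in this read-out.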

Compound 4, half-maximal inhibitory concentration: 7450 nM
The estimate for compound 4 lay 1.2-fold (0.08 log units) above the measured number; low and high end bracket the measured number.
By their numbers in this assay, from the lowest: compounds 3 and 4 (each within the scatter of the next); then compound 2. At a limit, above all of these: compound 1.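

In this assay, the exchange of the two halogens gives no change at the digits printed from compound 3 to compound 4 (within the scatter), so 4-chlorophenyl and 4-bromophenyl cannot be told apart on this read-out. Bromo in place of nitro gives a 4.0-fold lower number from compound 2 to compound 4 (0.60 log units; beyond the scatter), which shows that the gap from the nitro compound holds for both halogens, not for chloro alone. With bromo held fixed, methyl in place of hydrogen on a saturated chain carbon bound to a saturated ring carbon gives an at least 6.7-fold lower number from compound 1 to compound 4 (0.82 log units; beyond the scatter), the first sign that this second place matters too, though that size is only a lower bound since compound 1 stands at a limit: the limit of > 50000 nM in this assay, at which 1 of the 4 values shown sits.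

From the compounds shown here alone, what an amine or a carboxylic acid would read in place of the halogen remains open. So does whether a longer chain on the saturated ring carbon would carry the trend further.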